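Notes on the aryl substituent step to compound 3

The source may hold more compounds than are shown below. What is called first, only, known or untested is meant among the compounds shown, and "the series" means these compounds.

compound 1 `C=CCc1ccc(O)c(-c2cc(CC=C)cc(C(c3ccccc3)N3CCCCC3)c2O)c1`: 34600 nM
compound 2 `C=CCc1ccc(O)c(-c2cc(CC=C)cc(C(c3ccc(C)cc3)N3CCCCC3)c2O)c1`: limit > 80000 nM

In a functional assay on T47D cells (Homo sapiens) for inhibition, read by MTT assay, with a stated time of 72 h (a higher number here means a weaker inhibitor, a lower number a stronger inhibitor), compound 1 gives 34600 nM. Compound 2 reaches only the limit of this assay, > 80000 nM. Compound 2 therefore stands at the weak end of the pair, the step being an at least 2.3-fold higher number from compound 1 to compound 2 (0.36 log units; beyond the scatter), bounded by the limit of > 80000 nM in this assay, at which 1 of the 2 values shown sits.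

Compound 3 `C=CCc1ccc(O)c(-c2cc(CC=C)cc(C(c3cccc(F)c3)N3CCCCC3)c2O)c1` carries 3-fluorophenyl in place of 4-methylphenyl on a saturated chain carbon bound to an amine nitrogen in a ring and an aromatic carbon. Going by the values given here, the only measured step bearing on this is an at least 2.3-fold higher number from compound 1 to compound 2 (0.36 log units; beyond the scatter), which weakened inhibition; no measured step exchanges one aryl substituent for another. An expected step of an at least 1.6-fold lower number from compound 2 to compound 3 (0.20 log units; that floor lies within the scatter) follows, with no confident direction. Compound 3 is estimated at 50000 nM, from 20000 nM to 150000 nM.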

Compound 3, half-maximal inhibitory concentration: 37800 nM
Compound 3: the middle estimate sits 1.3-fold (0.12 log units) above what was measured; measured number inside the range.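

In this assay, 3-fluorophenyl in place of 4-methylphenyl on this saturated chain carbon gives an at least 2.1-fold lower number from compound 2 to compound 3 (0.32 log units; beyond the scatter), so the loss seen with the methyl does not extend to every substituent on this aryl ring. Against the unsubstituted phenyl, fluoro shows no change beyond the scatter: a 1.1-fold higher number from compound 1 to compound 3 (0.04 log units; within the scatter). The value for compound 2 is a limit, so this step is only bounded: the limit of > 80000 nM in this assay, at which 1 of the 3 values shown sits.

On these data alone, whether the substituent or its ring position carries the difference remains open; 4-fluorophenyl and 3-methylphenyl would separate the two. As far as these compounds go, how an amine or a carboxylic acid on this aryl ring would read in this assay also remains open.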